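Diallylamino in place of benzyl on the chain

A few compounds are considered here, and "the series" means these few. Any claim that something is new, unique, unknown or untested is made for them only; others in the source may bear on it.

In a functional assay on MGC-803 cells (Homo sapiens) for cytotoxicity, read by MTT assay, with a stated time of 48 h (a higher number here means a weaker inhibitor, a lower number a stronger inhibitor), compound 1 `CC1=NN(C(=O)CCl)C(c2cc(Br)ccc2O)C1` gives 13500 nM and compound 2 `CCC(=O)N1N=C(C)CC1c1cc(Br)ccc1O` gives 50300 nM under the same conditions. Compound 3 `CC1=NN(C(=O)CCc2ccccc2)C(c2cc(Br)ccc2O)C1` gives 21200 nM on that scale. Set against the other two, the numbers show a 1.6-fold higher number from compound 1 to compound 3 (0.20 log units; within the scatter) and also a 2.4-fold lower number from compound 2 to compound 3 (0.38 log units; beyond the scatter) in this small set.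

Compound 4 `C=CCN(CC=C)CC(=O)N1N=C(C)CC1c1cc(Br)ccc1O` has diallylamino in place of benzyl on a saturated chain carbon bound to a carbonyl carbon and has no measured value yet. Going by the values given here, the steps that bear on it are those at the same place, and the largest of them is a 3.7-fold higher number from compound 1 to compound 2 (0.57 log units; beyond the scatter) here. None of them involves diallylamino, so the direction of the change is not set by the data. The estimated step is a 1.2-fold lower number from compound 3 to compound 4 (0.07 log units; within the scatter) and no clear shift beyond the scatter is expected in this assay from this change, though a modest step of either sign remains possible. For compound 4 the expected value is 18000 nM with an estimated range of 6000 nM to 50000 nM in this read-out.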

Compound 4, half-maximal inhibitory concentration: 10200 nM
Estimate against measurement, compound 4: 1.8-fold (0.25 log units) above; the measured number falls inside the stated range.
By their numbers in this assay, from the lowest: compounds 4, 1 and 3 (each within the scatter of the next, the first and the last beyond it); then compound 2.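

In this assay, going by these compounds alone, diallylamino is the first group holding a nitrogen on this saturated chain carbon bound to a carbonyl carbon, and its exchange for benzyl, with the heavy-atom count unchanged, gives a 2.1-fold lower number from compound 3 to compound 4 (0.32 log units; beyond the scatter). The exchange for methyl gives a 4.9-fold lower number from compound 2 to compound 4 (0.69 log units; beyond the scatter), whereas the exchange for chloro gives a 1.3-fold lower number from compound 1 to compound 4 (0.12 log units; within the scatter), so diallylamino and chloro cannot be separated in this assay, and compound 2 remains the weakest of the four. No measurement available here explains these steps.

The compounds shown do not separate the contribution of the nitrogen from that of the two allyl groups, a question that dipropylamino or morpholine at this place would address. Also open, going by these compounds, is whether a longer chain between the carbonyl and the amine would change the value.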